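Tert-Butyl in Place of Propyl on the Fused Core

The source may report more compounds than this note shows. Statements on the series, on what has been measured and on what is new or still open speak of the compounds shown alone.

The measured compounds and their values:
- compound 1 `Cc1cc(OCc2ccccc2)c2nc(C)c(C)n2c1`, which gives 71% in a functional assay on the whole organism with Canis familiaris (Canis lupus familiaris) as the target, at a dose of 8 mg/kg by the oral route; a higher number here means a stronger effect of the compound at the dose given, a lower number a weaker effect
- compound 2 `CCc1nc2c(OCc3ccccc3)cccn2c1N`, which gives 59% in this assay
- compound 3 `CCCc1nc2c(OCc3ccccc3)cccn2c1N`, which gives 0% in this assay

Compound 3 stands lowest of the three numbers. Its nearest neighbour is compound 2, and compound 1 lies furthest from it; both gaps are beyond the scatter.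

The unmeasured compound 4 `CC(C)(C)c1nc2c(OCc3ccccc3)cccn2c1N` differs from compound 3 in one place: tert-butyl in place of propyl on an aromatic carbon. The group sits on an aromatic carbon of a five-membered aromatic ring with two nitrogen atoms, next to the ring nitrogen and next to the ring atom that bears the amino group.

Among the measured compounds shown here, only one measured step touches this position, and it runs the other way: a number 59 percentage points lower from compound 2 to compound 3 (beyond the scatter), a large drop for adding a single carbon to the chain. For the measured compounds named here, compound 3 already shows no inhibition, so a further enlargement of the group can hardly lower the number, and there is no measured step that points upward. The account therefore expects compound 4 to show a step of a number 5 percentage points higher from compound 3 to compound 4 (within the scatter) in this assay, that is, no change beyond the scatter. For compound 4 the estimate in this assay is 5%, with a range from 0% to 25%.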

Compound 4, a percentage reported as inhibition, in the whole organism at one dose (the size of the read-out at that dose, not a potency): 0%
Compound 4: the middle estimate sits 5 percentage points above what was measured, within the range that was stated.
By their numbers in this assay, from the lowest: compounds 3 and 4 (each within the scatter of the next); then compound 2; then compound 1.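

In this assay, tert-butyl in place of propyl gives no change at the digits printed from compound 3 to compound 4 (within the scatter), so the branched group on this aromatic carbon ends at the same reading as the straight chain, and compound 4 gives 0%. Set against the ethyl group, the same change gives a number 59 percentage points lower from compound 2 to compound 4 (beyond the scatter), which shows that the loss seen with propyl is not confined to that one chain: among the three compounds that differ only at this carbon, ethyl alone retains inhibition at the dose given, while propyl and tert-butyl both read zero and cannot be told apart. The data on hand offer no explanation for why inhibition disappears with these two groups.

The compounds shown leave open whether a methyl group, a cyclopropyl ring or a methoxymethyl chain on this carbon would keep, raise or lose the inhibition that ethyl gives. They also leave open whether compound 3 and compound 4 would show any inhibition at another dose, since a reading at one dose is not a potency.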